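From a Methylthiophene to a Hydroxyphenyl Chain End

The source may report more compounds than this note shows. Statements on the series, on what has been measured and on what is new or still open speak of the compounds shown alone.

In a functional assay on MCF7 cells (Homo sapiens) for cytotoxicity (a higher number here means a weaker inhibitor, a lower number a stronger inhibitor), compound 1 `C=C/C=C\[C@H](C)[C@H](OC(N)=O)[C@@H](C)[C@H](O)[C@@H](C)C/C(C)=C\[C@H](C)[C@@H](O)[C@@H](C)/C=C\CCc1ccc(C)c(F)c1` gives 1000 nM while compound 2 `C=C/C=C\[C@H](C)[C@H](OC(N)=O)[C@@H](C)[C@H](O)[C@@H](C)C/C(C)=C\[C@H](C)[C@@H](O)[C@@H](C)/C=C\CCc1sccc1C` gives 370 nM and so holds the lower of the two numbers, which means the stronger inhibition of the pair. Compound 3 `C=C/C=C\[C@H](C)[C@H](OC(N)=O)[C@@H](C)[C@H](O)[C@@H](C)C/C(C)=C\[C@H](C)[C@@H](O)[C@@H](C)/C=C\CCc1cccc(O)c1` keeps the shared core and alters only the group at the end of the chain. The change from compound 2 reads 3-hydroxyphenyl in place of 3-methylthiophen-2-yl on a saturated chain carbon, two bonds along the chain from a double-bonded chain carbon and sits on a saturated chain carbon, two bonds along the chain from a double-bonded chain carbon. Going by the values given here, only one measured step bears on this swap, namely a 2.7-fold lower number from compound 1 to compound 2 (0.43 log units; beyond the scatter) at that same place, and it is modest. Among the compounds with values here, compound 3 returns to a carbon-only six-membered aromatic ring, as in compound 1, but its hydroxy group has no measured precedent, so this single step is thin evidence. A small rise is therefore expected, with the estimated change being a 1.5-fold higher number from compound 2 to compound 3 (0.17 log units; within the scatter) and no clear move beyond the scatter anticipated. In this assay compound 3 is expected at 550 nM with a range from 170 nM to 1800 nM as the estimate.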

Compound 3, half-maximal inhibitory concentration: 130 nM
For compound 3 the middle estimate is 4.2-fold (0.63 log units) above the measured one; the measured number lies below the stated range.
By their numbers in this assay, from the lowest: compound 3; then compound 2; then compound 1.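

In this assay, the group at the end of the chain moves the number further than compound 1 and compound 2 alone could show: 3-hydroxyphenyl in place of 3-methylthiophen-2-yl gives a 2.8-fold lower number from compound 2 to compound 3 (0.45 log units; beyond the scatter) at this place. A return to a carbon-only six-membered aromatic ring does not by itself bring back the higher number of compound 1, as 3-hydroxyphenyl in place of 3-fluoro-4-methylphenyl gives a 7.7-fold lower number from compound 1 to compound 3 (0.89 log units; beyond the scatter) on the same chain carbon. Compound 1 and compound 3 both carry that kind of ring yet stand at opposite ends of the three, with the five-membered ring of compound 2 in the middle, so ring type alone does not set the order here. Nothing available explains why compound 3 holds the lowest number.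

Compound 1 and compound 3 differ in all their ring substituents at once, so these three compounds cannot separate the gain from having the hydroxy group from the loss of the fluoro and methyl groups. An unsubstituted phenyl ring would help to separate them, and an amine or a methoxy group in place of the hydroxy group would test how specific the hydroxy group is.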